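The source may hold more compounds than are shown below. What is called first, only, known or untested is meant among the compounds shown, and "the series" means these compounds.

Series notes, cytotoxicity on the shared core of compound 2 `Cc1ccccc1-c1nn(-c2ccc(F)cc2F)cc1CNCCN1CCN(C)CC1`.

Compound 1 `CN1CCN(CCNCc2cn(-c3ccc(F)cc3F)nc2-c2ccc(S(=O)(=O)N(C)C)cc2)CC1` gives in an ADME assay on Huh-7 cells (Homo sapiens) for cytotoxicity (a lower number here means that less compound is tolerated, a higher number that more compound is tolerated), only a limit of the assay, namely > 20000 nM. Compound 2 likewise gives only a limit, > 20000 nM, so its standing on the numbers shown is that of the limit of > 20000 nM in this assay, at which 2 of the 3 values shown sit. Compound 3 `Cc1ccccc1-c1nn(-c2ccc(Br)cc2)cc1CNCCN1CCN(C)CC1` gives a number, 9600 nM. The step that the two limits leave unreadable from compound 1 to compound 2; the step of an at least 2.0-fold lower number from compound 2 to compound 3 (0.31 log units; beyond the scatter).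

Compound 4 `Cc1ccccc1-c1nn(-c2ccc(F)cc2F)cc1CNC1CCN(S(C)(=O)=O)CC1` is not yet measured. It differs from compound 2 by 1-(methylsulfonyl)piperidin-4-yl in place of 2-(4-methylpiperazin-1-yl)ethyl on an amine nitrogen. For the measured compounds named here, no measured step touches this amine nitrogen: the step from compound 1 to compound 2 changes an aromatic carbon substituent and is unreadable because of the limit of > 20000 nM in this assay, at which 2 of the 3 values shown sit, and the step from compound 2 to compound 3 changes the group on the aromatic nitrogen. Neither bears directly on the change to compound 4, so no step beyond the scatter in this assay is expected, in either direction; the expected step is a number no higher from compound 2 to compound 4 (the limit leaves the size open). Compound 4 is therefore estimated at 20000 nM, within 10000 nM to 40000 nM, most likely reported again as a limit.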

Compound 4, half-maximal cytotoxic concentration: > 20000 nM
Compound 4: no number, only a limit (the forecaster's own chance of this, stated with the estimate: 70%); the middle value sits exactly at the limit.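

Compound 2 and compound 4 both give only a limit in this assay, so no step between them can be read, because both sit at the same limit: the limit of > 20000 nM in this assay, at which 3 of the 4 values shown sit.

The compounds shown leave open whether 1-(methylsulfonyl)piperidin-4-yl in place of 2-(4-methylpiperazin-1-yl)ethyl on the amine nitrogen changes the number in this assay at all, and in which direction.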